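A primary amine in place of a dimethylamino group

A few compounds are considered here, and "the series" means these few. Any claim that something is new, unique, unknown or untested is made for them only; others in the source may bear on it.

Of the compounds shown here, two built on an allene chain have been tested in an assay on isolated protein for inhibition of Monoamine oxidase (Rattus norvegicus); on this read-out higher numbers stand for weaker inhibition and lower numbers for stronger inhibition. Compound 1 `C=C=CCN(C)Cc1ccccc1` gives 170 nM in this assay. Compound 2 `C=C=C(Cc1ccccc1)CN(C)C` carries its amine on a different part of the chain, and in this assay compound 2 reaches only the limit of > 100000 nM, so no number is known for it; it is the limit of > 100000 nM in this assay, at which 1 of the 2 values shown sits. Compound 2 therefore stands at the weak end of what has been measured.

Compound 3 `C=C=C(CN)Cc1ccccc1` differs from compound 2 by amino in place of dimethylamino on a saturated chain carbon bound to a double-bonded chain carbon. No measured step of this kind exists among the compounds shown. Because compound 2 sits at the limit of > 100000 nM, any measurable number for compound 3 would be a step toward stronger inhibition. Compound 3 is expected to come in at 1500 nM, within 100 nM to 30000 nM, which would be an estimated step of an at least 66-fold lower number from compound 2 to compound 3 (1.82 log units; beyond the scatter).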

Compound 3, half-maximal inhibitory concentration: 140 nM
The estimate for compound 3 lay 11-fold (1.03 log units) above the measured number; the range from low to high includes it.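

On a saturated chain carbon bound to a double-bonded chain carbon, putting amino in place of dimethylamino gives in this assay an at least 710-fold lower number from compound 2 to compound 3 (2.85 log units; beyond the scatter) and so turns a compound without a measurable number into one with a clear number. Within the data shown here, this single change therefore has a very large effect at this position, which the earlier compounds could not show, as they offered no step of any kind. Going by these compounds, the true size of the step stays unknown, and it could be larger still, because the value for compound 2 is a limit and not a number: the limit of > 100000 nM in this assay, at which 1 of the 3 values shown sits.

The methylamino group, which carries one methyl on the nitrogen, could land near compound 3, near the limit of compound 2, or somewhere in between. An ethylamino group, or a longer chain between the amine and the allene, also remains an open question at this position.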